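The source may hold more compounds than are shown below. What is called first, only, known or untested is meant among the compounds shown, and "the series" means these compounds.

Of the compounds shown here, three have been measured in an assay on CHO-K1 cells for displacement of a labelled ligand from melanin-concentrating hormone receptor 1 (Homo sapiens), read by scintillation proximity assay, with a stated time of 2 h; on this read-out lower numbers stand for stronger inhibition and higher numbers for weaker inhibition. Compound 1, `C/C(=C\C(=O)Nc1ccc2nc(N3CCC(O)(C4CC4)CC3)nc(C)c2c1)c1ccc(Cl)cc1`, gives 532 nM. Compound 2, `CCCC1(O)CCN(c2nc(C)c3cc(NC(=O)/C=C/c4ccc(Cl)cc4)ccc3n2)CC1`, gives 245 nM. Compound 3, `Cc1nc(NCCNC(=O)C2CC2)nc2ccc(NC(=O)/C=C/c3ccc(OC(F)(F)F)cc3)cc12`, gives 61 nM, the lowest number of the three; its gaps to compound 2 and to compound 1 both lie well beyond the usual scatter of this assay, so compound 3 stands as the strongest binder of the set.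

The next compound, compound 4, `Cc1nc(N2CCC(N3CCCC3=O)CC2)nc2ccc(NC(=O)/C=C/c3ccc(OC(F)(F)F)cc3)cc12`, has not yet been measured. It keeps the whole of compound 3 except for one change: 4-(2-oxopyrrolidin-1-yl)piperidin-1-yl in place of (2-((cyclopropylcarbonyl)amino)ethyl)amino on an aromatic carbon. The chain carrying an amide hydrogen and a cyclopropyl group is thus swapped for two linked saturated rings with no hydrogen-bond donor at all.

Among the measured compounds shown here, no measured pair shows exactly this swap, so the expected direction is uncertain. Compounds 1 and 2 also carry a six-membered saturated ring with one nitrogen at this position, and they bind more weakly than compound 3, but they differ from it elsewhere too, so they give only a loose hint. The expected step is a 2.5-fold higher number from compound 3 to compound 4 (0.39 log units; beyond the scatter). Compound 4 is thus estimated at 150 nM, with a plausible range from 40 nM to 600 nM.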

Compound 4, half-maximal inhibitory concentration: 11 nM
Beside the measured number, compound 4's estimate is 14-fold (1.13 log units) above it, outside the stated range (below it).
By their numbers in this assay, from the lowest: compound 4; then compound 3; then compound 2; then compound 1.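

In this assay, among the compounds shown here, putting 4-(2-oxopyrrolidin-1-yl)piperidin-1-yl in place of (2-((cyclopropylcarbonyl)amino)ethyl)amino gives a 5.5-fold lower number from compound 3 to compound 4 (0.74 log units; beyond the scatter) and so a stronger result, the first direct reading of a change at this position. This aromatic carbon, between two ring nitrogen atoms, therefore accepts two linked saturated rings with 12 heavy atoms and 0 hydrogen-bond donors in place of a chain-bearing group with 9 heavy atoms and 2 hydrogen-bond donors, and binding does not suffer: the hydrogen-bond donors of the leaving group are not required for binding at the level seen with compound 3, and the larger group is accepted here. Nothing available explains why this swap lowers the number.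

The swap changes the ring content, the size and the hydrogen-bond donors all at once, so this single step cannot show which of these differences matters. A plain piperidin-1-yl group, or one carrying an amine or a carboxylic acid in place of the 2-oxopyrrolidin-1-yl ring, would help to separate the contribution of the piperidine ring from that of the lactam ring on it.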